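The source may report more compounds than this note shows. Statements on the series, on what has been measured and on what is new or still open speak of the compounds shown alone.

Measured in a functional assay on HCT-116 cells (Homo sapiens) for inhibition, read by sulforhodamine B assay, with a stated time of 48 h; on this read-out lower numbers stand for stronger inhibition of growth and higher numbers for weaker inhibition of growth:

- Compound 1 `CC(C)c1cc(C(=O)Nc2cccc(NC(=O)CCCCCCC(=O)NO)c2)c(O)cc1O`: 6230 nM
- Compound 2 `CC(C)c1cc(C(=O)N(C)c2ccc(NC(=O)CCCCCCCCC(=O)NO)cc2)c(O)cc1O`: 590 nM

Of these two, compound 2 carries the lower number, 590 nM, and so shows the stronger inhibition of growth, with a gap to compound 1 that lies beyond the scatter. The next compound to be tested is compound 3 `CC(C)c1cc(C(=O)N(C)c2ccc(NC(=O)CCCCCCC(=O)NO)cc2)c(O)cc1O`, which departs from compound 2 in one place only: hydroxycarbamoyl in place of 2-(hydroxycarbamoyl)ethyl on a saturated chain carbon, six bonds along the chain from a carbonyl carbon. Hydroxycarbamoyl stands in place of 2-(hydroxycarbamoyl)ethyl on a saturated chain carbon, six bonds along the chain from a carbonyl carbon, so the chain comes out shorter.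

Among the compounds with values here, no measured pair isolates this change, and the data therefore do not show its size directly. A moderate move towards a higher number, meaning weaker inhibition, is expected, and the only other measured point is compound 1 at 6230 nM. The expected size of the step is a 2.2-fold higher number from compound 2 to compound 3 (0.34 log units; beyond the scatter), which may not lie far beyond the scatter. In this assay the estimated value for compound 3 is 1300 nM, with an expected range from 450 nM to 3800 nM.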

Compound 3, concentration for 50% growth inhibition: 830 nM
Estimate against measurement, compound 3: 1.6-fold (0.19 log units) above; measured number inside the range.
By their numbers in this assay, from the lowest: compounds 2 and 3 (each within the scatter of the next); then compound 1.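

In this assay, within the data shown here, hydroxycarbamoyl in place of 2-(hydroxycarbamoyl)ethyl on a saturated chain carbon, six bonds along the chain from a carbonyl carbon, gives a 1.4-fold higher number from compound 2 to compound 3 (0.15 log units; within the scatter) and is the first pair to isolate this change. At this position, the two chain lengths of compound 2 and compound 3 therefore cannot be told apart in this read-out. Compound 1 and compound 2 differ in more than one place. The data do not tell which of those differences goes with the gap that separated them. No measurement of any other kind bears on this result.

On these data alone, whether a longer chain than that of compound 2, a shorter chain than that of compound 3, or a carboxylic acid in place of the hydroxycarbamoyl end would change the number remains open. Compound 1 also differs from compound 3 in more than one place, so the compounds shown do not separate the contribution of the methyl group on the amide nitrogen from that of the other differences.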